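Ethyl-to-isopropyl urea change on the piperazine dithiocarbamate series

A few compounds are considered here, and "the series" means these few. Any claim that something is new, unique, unknown or untested is made for them only; others in the source may bear on it.

Compound 1 `CCN(C)C(=O)N1CCN(C(=S)SCc2cn(Cc3ccc(OC)cc3)nn2)CC1` in a functional assay on SMMC-7721 cells (Homo sapiens) for cytotoxicity, read by MTT assay, with a stated time of 72 h (a lower number here means a stronger inhibitor, a higher number a weaker inhibitor), gives > 128000 nM, which is a limit of the assay.
Compound 2 `COc1cc(Cn2cc(CSC(=S)N3CCN(C(N)=O)CC3)nn2)cc(OC)c1OC` in this assay gives > 128000 nM, again a limit.
Compound 3 `CCNC(=O)N1CCN(C(=S)SCc2cn(Cc3cc(OC)c(OC)c(OC)c3)nn2)CC1` in this assay gives > 128000 nM, also a limit and not a number.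

Compound 3 therefore stands nowhere readable on the numbers shown: all three values sit at the same limit (the limit of > 128000 nM in this assay, at which 3 of the 3 values shown sit), and none is a measured concentration. Among the measured compounds shown here, the one single-point step, a step that the two limits leave unreadable from compound 2 to compound 3, is unreadable for the same reason, so the effect of a substituent on the urea nitrogen has not been seen in either direction.

Compound 4 `COc1cc(Cn2cc(CSC(=S)N3CCN(C(=O)NC(C)C)CC3)nn2)cc(OC)c1OC` differs from compound 3 by methyl in place of hydrogen on a saturated chain carbon bound to an amide-type nitrogen and a saturated chain carbon. For the measured compounds named here, no measured step bears on this change; the only related step, from compound 2 to compound 3, gives no size. With every value in the series at the limit, the expectation is that the isopropyl urea behaves like the ethyl urea and the unsubstituted urea, and that this assay again reports no number. The step from compound 3 to compound 4 is expected to be a step that the limit leaves unreadable from compound 3 to compound 4, meaning no readable change. Compound 4 is estimated at 150000 nM, with a range of 60000 nM to 400000 nM, most probably returned as a limit.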

Compound 4, half-maximal inhibitory concentration: > 128000 nM
Compound 4 ended at the assay's limit (the forecaster's own chance of this, stated with the estimate: 85%); the middle value is on the limit's open side.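

No new step can be read: in this assay compound 2, compound 3 and compound 4 give limits and not numbers, so the steps among them cannot be read, and the whole series shares one limit: the limit of > 128000 nM in this assay, at which 4 of the 4 values shown sit.

As far as these compounds go, whether any substituent on the urea nitrogen, or any other change to the shared core, gives a measured concentration in this assay stays open.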